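This account rests on a few compounds, and the source may have more. Where it says the series, first, only, none or still open, it means among the compounds named here.

In a functional assay on M21 cells (Homo sapiens) for antiproliferative activity, read by sulforhodamine B assay, with a stated time of 48 h (a higher number here means a weaker inhibitor, a lower number a stronger inhibitor), compound 1 `Cc1ccccc1OS(=O)(=O)c1ccc(N2CCN(C)C2=O)cc1` gives 2900 nM, and compound 2 `COc1cc(OS(=O)(=O)c2ccc(N3CCN(C)C3=O)cc2)cc(OC)c1OC` gives the lower 54 nM. Compound 3 `CCCN1CCN(c2ccc(S(=O)(=O)Oc3ccccc3C)cc2)C1=O` stands only at a limit of the assay, > 100000 nM, and not at a number. Compound 4 `CCCN1CCN(c2ccc(S(=O)(=O)Oc3ccc(C)cc3C)cc2)C1=O` differs from compound 3 by methyl in place of hydrogen on an aromatic carbon, meta to a methyl group and para to a large group. Within the data shown here, the only measured single change is an at least 34-fold higher number from compound 1 to compound 3 (1.53 log units; beyond the scatter), a large loss made elsewhere in the molecule, so it bears on this change only indirectly. Among the measured compounds shown here, no measured step tests the new methyl itself, and it is expected to recover little of that loss. For compound 4 the estimated value is 80000 nM, with an expected range of 15000 nM to 150000 nM. The expected change is an at least 1.2-fold lower number from compound 3 to compound 4 (0.09 log units; that floor lies within the scatter).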

Compound 4, half-maximal inhibitory concentration: 9700 nM
Beside the measured number, compound 4's estimate is 8.2-fold (0.92 log units) above it, and the stated range ends above it.
By their numbers in this assay, from the lowest: compound 2; then compound 1; then compound 4. At a limit, above all of these: compound 3.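

In this assay, the change from 2-methylphenyl to 2,4-dimethylphenyl gives an at least 10-fold lower number from compound 3 to compound 4 (1.01 log units; beyond the scatter). The earlier step changed only the chain on the ring nitrogen, whereas this one shows that a single methyl on the aromatic ring, para to a large group, can also move the number by a large amount. Compound 3 stands at a limit and not at a number, so this size is only a floor: the limit of > 100000 nM in this assay, at which 1 of the 4 values shown sits.

The compounds shown leave open whether a methoxy group, a chlorine atom or an amine at this position would act like methyl. They also leave open whether the same methyl would change the number for compound 1.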